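Methylating the Hydroxy Group of Compound 2

This account rests on a few compounds, and the source may have more. Where it says the series, first, only, none or still open, it means among the compounds named here.

For the measured compounds named here, in a functional assay on MCF7 cells (Homo sapiens) for antiproliferative activity, read by MTT assay, with a stated time of 72 h (on this read-out higher numbers stand for weaker inhibition and lower numbers for stronger inhibition), compound 2 (`O=C(N/N=C/c1ccc(O)cc1)Nc1ccc(Oc2ccnc3[nH]ccc23)cc1`) gives 5800 nM and thereby supplies the only number in this small series. Compound 1 (`O=C(N/N=C/c1ccc(Br)cc1)Nc1ccc(Oc2ccnc3[nH]ccc23)cc1`) is recorded as "not active" (no number reported) with no number attached, so compound 2 has no measured neighbour against which it could be ranked.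

Compound 3 (`COc1ccc(/C=N/NC(=O)Nc2ccc(Oc3ccnc4[nH]ccc34)cc2)cc1`) carries a methyl in place of hydrogen on an oxygen on an aromatic ring, which turns the 4-hydroxyphenyl of compound 2 into 4-methoxyphenyl (methyl in place of hydrogen on an oxygen on an aromatic ring). Going by the values given here, no measured step speaks directly to this change, so the expectation in this assay is a cautious one: a small shift towards weaker inhibition, no larger than the usual scatter. Compound 2 at 5800 nM still gives a number, yet the series also holds an entry without one, so a result without a number for compound 3 remains possible. The estimate corresponds to a 1.2-fold higher number from compound 2 to compound 3 (0.08 log units; within the scatter) and this expected step stays within the scatter. In this assay the estimated value for compound 3 is 7000 nM (expected range 2500 nM to 20000 nM).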

Compound 3, half-maximal inhibitory concentration: "not active" (no number reported)
Nothing numeric was reported for compound 3; the estimate stays without a comparison.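

In this assay, for the compounds shown here, compound 3 is recorded as "not active" (no number reported) and compound 2 gives 5800 nM so no step between the two can be read. The compounds shown leave open how large the effect of going from hydroxy to methoxy is on this read-out. Nothing shown here offers an explanation for this result.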